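Trimming the piperazine nitrogen substituent to hydrogen

A few compounds are considered here, and "the series" means these few. Any claim that something is new, unique, unknown or untested is made for them only; others in the source may bear on it.

Measured compounds in a functional assay on CHO-K1 cells for antagonist activity at Urotensin-2 receptor (Rattus norvegicus), read by FLIPR and calcium flux, with a stated time of 1 h; on this read-out higher numbers stand for weaker inhibition and lower numbers for stronger inhibition:
- Compound 1 `COc1ccc([C@@H](CCCN(C)S(=O)(=O)c2cccs2)N2Cc3c(cccc3N3CCN(C4CCC4)CC3)C2=O)cc1OC`: 4 nM
- Compound 2 `COc1ccc([C@@H](CCCN(C)S(=O)(=O)c2cccs2)N2Cc3c(cccc3N3CCN(C)CC3)C2=O)cc1OC`: 16 nM
- Compound 3 `CCN1CCN(c2cccc3c2CN([C@H](CCCN(C)S(=O)(=O)c2cccs2)c2ccc(OC)c(OC)c2)C3=O)CC1`: 7 nM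

Compound 3 gives the second-highest of the three numbers in this assay. Its nearest neighbour is compound 1, the step of a 1.8-fold higher number from compound 1 to compound 3 (0.24 log units; within the scatter), which lies within the scatter. Its furthest neighbour is compound 2, and the step of a 2.3-fold lower number from compound 2 to compound 3 (0.36 log units; beyond the scatter) lies beyond the scatter.

Compound 4 `COc1ccc([C@@H](CCCN(C)S(=O)(=O)c2cccs2)N2Cc3c(cccc3N3CCNCC3)C2=O)cc1OC` differs from compound 3 by hydrogen in place of ethyl on an amine nitrogen in a ring. Within the data shown here, the steps that bear on this change all concern the group on that same ring nitrogen: a 4.0-fold higher number from compound 1 to compound 2 (0.60 log units; beyond the scatter) and a 2.3-fold lower number from compound 2 to compound 3 (0.36 log units; beyond the scatter) both show that a smaller group on this nitrogen goes with a higher number, while a 1.8-fold higher number from compound 1 to compound 3 (0.24 log units; within the scatter) is within the scatter. Going from ethyl to hydrogen is a further reduction in the same direction, so compound 4 is expected to give a higher number than compound 3, by a step of about a 5.7-fold higher number from compound 3 to compound 4 (0.76 log units; beyond the scatter). The estimate for compound 4 is 40 nM, with a range from 12 nM to 150 nM.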

Compound 4, half-maximal inhibitory concentration: 39 nM
Beside the measured number, compound 4's estimate is 1.0-fold (0.01 log units) above it; the range from low to high includes it.
By their numbers in this assay, from the lowest: compounds 1 and 3 (each within the scatter of the next); then compound 2; then compound 4.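

With hydrogen on this ring nitrogen, the comparison now reaches a piperazin-1-yl carrying no alkyl group at all. In this assay, the change gives a 5.6-fold higher number from compound 3 to compound 4 (0.75 log units; beyond the scatter) when it replaces ethyl, a 2.4-fold higher number from compound 2 to compound 4 (0.39 log units; beyond the scatter) when it replaces methyl and a 9.8-fold higher number from compound 1 to compound 4 (0.99 log units; beyond the scatter) when it replaces cyclobutyl. Among these compounds, each step lies beyond the scatter, so compound 4 is the weakest of the four, and each of the three alkyl groups goes with a lower number than hydrogen, which the earlier compounds, all alkylated at this nitrogen, could not show.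

Going by these compounds, whether a longer chain such as n-butyl, a larger ring such as cyclohexyl or an acetyl group on this nitrogen would lower the number further stays open. Nothing available explains why hydrogen goes with the highest number.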